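A Methyl Swapped for Hydrogen at the Assay Limit

This account rests on a few compounds, and the source may have more. Where it says the series, first, only, none or still open, it means among the compounds named here.

Measured so far:
Compound 1 `Nc1ccn([C@@H]2S[C@H](CO)C=C2F)c(=O)n1`: > 100000 nM
Compound 2 `Cc1cn([C@@H]2S[C@H](CO)C=C2F)c(=O)nc1O`: > 100000 nM

Both compounds were tested in an ADME assay on CCRF-CEM cells (Homo sapiens) for cytotoxicity; a lower number here means a stronger inhibitor, a higher number a weaker inhibitor. Neither result is a exact number, and the pattern is simple to state: the limit of > 100000 nM in this assay, at which 2 of the 2 values shown sit.

In this assay compound 2 gives > 100000 nM, which is a limit of the assay and not a number. Compound 1 gives > 100000 nM, which is also a limit.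

The next compound to be tested is compound 3 `O=c1nc(O)ccn1[C@@H]1S[C@H](CO)C=C1F`. It differs from compound 2 in a single place: hydrogen in place of methyl on an aromatic carbon. In words, hydrogen stands in place of methyl on an aromatic carbon.

Among the measured compounds shown here, no two measured compounds differ in one place, so the data hold no direct guide to the size of this change. With only limits in hand, no step beyond the usual scatter is expected in this assay, and any shift could go in either direction. The expected a number no higher from compound 2 to compound 3 (the limit leaves the size open) is therefore small. For compound 3 the estimated value is 100000 nM, with an expected range from 40000 nM to 200000 nM.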

Compound 3, half-maximal inhibitory concentration: > 100000 nM
Compound 3 was reported as a limit; the forecaster's own chance of this, stated with the estimate: 85%; the middle value lies on the limit itself.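

The steps from compound 3 to compound 2 and to compound 1 cannot be read in this assay, because these results are limits of the assay and not numbers: the limit of > 100000 nM in this assay, at which 3 of the 3 values shown sit.

The compounds shown leave open whether hydrogen in place of methyl, or hydroxy in place of amino, on an aromatic carbon changes the result in this assay at all.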